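Clearance of Compound 4, a Pyridin-3-yl Amide

This account rests on a few compounds, and the source may have more. Where it says the series, first, only, none or still open, it means among the compounds named here.

Measured compounds:
- compound 1 `CN1C[C@H](C(=O)Nc2ccc(Br)cc2)[C@@H](c2ccc(/C=C/C(=O)Nc3ccccc3N)cc2)C1`: 3 mL/min/kg
- compound 2 `Cc1cccc(NC(=O)[C@H]2CN(C)C[C@@H]2c2ccc(/C=C/C(=O)Nc3ccccc3N)cc2)c1`: 14 mL/min/kg
- compound 3 `CN1C[C@H](C(=O)Nc2ccc(Cl)c(Cl)c2)[C@@H](c2ccc(/C=C/C(=O)Nc3ccccc3N)cc2)C1`: 14 mL/min/kg

These three share one core and differ only in the aryl group on an amide-type nitrogen. In an in vitro ADME assay on microsomes from liver (Homo sapiens) for pharmacokinetics, read by LC-MS, with a stated time of 10 min, tested at 1 uM (on this read-out lower numbers stand for slow clearance and higher numbers for fast clearance), compound 2 gives 14 mL/min/kg, level with compound 3 and together with it the highest of the three numbers, while the step of a 4.7-fold higher number from compound 1 to compound 2 (0.67 log units; beyond the scatter) is beyond the scatter and modest in size. The step of no change at the digits printed from compound 2 to compound 3 (within the scatter) is within the scatter, and a 4.7-fold higher number from compound 1 to compound 3 (0.67 log units; beyond the scatter) matches the first step.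

Compound 4 `CN1C[C@H](C(=O)Nc2cccnc2)[C@@H](c2ccc(/C=C/C(=O)Nc3ccccc3N)cc2)C1` is not yet measured. It differs from compound 2 in this way: pyridin-3-yl in place of 3-methylphenyl on an amide-type nitrogen

Among the measured compounds shown here, no measured step swaps a carbon-only ring for a ring holding a nitrogen, so no step bears directly on this change. What the measured steps show is that changing the aryl group on this nitrogen moves clearance by a modest amount at most. The expectation is therefore a number near that of compound 2, or a little lower, with a wide range. Compound 4 is estimated at 9 mL/min/kg, within 3 mL/min/kg to 25 mL/min/kg, an expected step of a 1.6-fold lower number from compound 2 to compound 4 (0.19 log units; within the scatter).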

Compound 4, clearance: 10 mL/min/kg
The estimate for compound 4 lay 1.1-fold (0.05 log units) below the measured number; the measured number falls inside the stated range.
By their numbers in this assay, from the lowest: compound 1; then compounds 4, 2 and 3 (each within the scatter of the next).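

In this assay, the first ring holding a nitrogen at this position can't be told apart from the carbon-only rings of compounds 2 and 3: the change reads as a 1.4-fold lower number from compound 2 to compound 4 (0.15 log units; within the scatter) and as a 1.4-fold lower number from compound 3 to compound 4 (0.15 log units; within the scatter) in the two comparisons. So pyridin-3-yl, with its ring nitrogen and its hydrogen-bond acceptor, joins 3-methylphenyl and 3,4-dichlorophenyl as a group that gives a similar clearance here, while the comparison with the remaining compound reads a 3.3-fold higher number from compound 1 to compound 4 (0.52 log units; beyond the scatter) and leaves 4-bromophenyl as the only one of the four groups set apart from the others. No measurement shown gives a reason for this grouping or for the low number of compound 1.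

Whether the ring nitrogen can be moved without consequence remains open, as pyridin-2-yl and pyridin-4-yl do not appear among these compounds. Also open, on these data alone, is whether the low clearance of compound 1 belongs to bromine itself or to any single group at that ring position, a question that 4-chlorophenyl or 4-methylphenyl would address, and how a ring carrying an amine or a carboxylic acid would behave.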